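A few compounds are considered here, and "the series" means these few. Any claim that something is new, unique, unknown or untested is made for them only; others in the source may bear on it.

- compound 1 `COc1cccc(S(=O)(=O)/C=C/c2cccnc2)c1` gives 75% as its number
- compound 2 `COc1cccc(S(=O)(=O)/C=C/c2cccnc2Cl)c1` gives 29% as its number
- compound 3 `COc1cccc(S(=O)(=O)/C=C/c2cncnc2)c1` is still to be measured

In an ADME assay on microsomes from liver (Homo sapiens) for metabolic stability, read by LC-MS, using NADPH, with stated times of 5 min and 30 min, tested at 1 uM (on this read-out lower numbers stand for a less stable compound and higher numbers for a more stable compound), compound 1 stands higher of the two measured compounds, with 75% as its number. The move to compound 3 is pyrimidin-5-yl in place of pyridin-3-yl on a double-bonded chain carbon bound to a double-bonded chain carbon and nothing else changes: pyrimidin-5-yl in place of pyridin-3-yl on a double-bonded chain carbon bound to a double-bonded chain carbon. Going by the values given here, only one measured step bears on this, and only loosely. The step of a number 46 percentage points lower from compound 1 to compound 2 (beyond the scatter) is large and beyond the scatter, with chloro in place of hydrogen on an aromatic carbon of that same pyridin-3-yl group. It shows that a change there can matter, but adding chloro is a different change and gives no direction for compound 3. The expected result is a number 3 percentage points lower from compound 1 to compound 3 (within the scatter) in this assay, so no step beyond the scatter is expected. For compound 3 the estimated number is 72% with an expected range from 48% to 90% overall.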

Compound 3, percent of the compound remaining: 96%
Beside the measured number, compound 3's estimate is 24 percentage points below it, and the stated range ends below it.
By their numbers in this assay, from the lowest: compound 2; then compound 1; then compound 3.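

In this assay, going by these compounds alone, the earlier compounds showed only that adding chloro to the pyridin-3-yl group goes with a fall (a number 46 percentage points lower from compound 1 to compound 2 (beyond the scatter)). Putting pyrimidin-5-yl in place of that whole group moves the number the other way (a number 21 percentage points higher from compound 1 to compound 3 (beyond the scatter)). This place on the double-bonded chain carbon can therefore go with a more stable compound as well as a less stable one, and the modest step lies beyond the usual scatter.

Nothing available here accounts for this rise.

The compounds shown leave open whether a plain phenyl ring at this place would give a number closer to compound 1 or to compound 3. They also leave open whether an amine on the pyrimidin-5-yl group would keep the higher number.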